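This account rests on a few compounds, and the source may have more. Where it says the series, first, only, none or still open, it means among the compounds named here.

Measured compounds:
compound 1 `COc1cc(-c2cc(/C=C/C(=O)c3ccc(N)cc3)[nH]n2)cc(OC)c1OC` — 83%
compound 2 `COc1ccc(-c2cc(/C=C/C(=O)c3ccc(N)cc3)[nH]n2)cc1OC` — 85%

In a functional assay on T47D cells (Homo sapiens) for cytotoxicity, read by sulforhodamine B assay, with a stated time of 48 h, tested at 0.01 uM (on this read-out higher numbers stand for a weaker effect at the one concentration tested and lower numbers for a stronger effect), compound 1 gives 83%, and compound 2 gives 85%. Among the measured compounds shown here, compound 1 thus stands within the scatter of the only other measured compound, so the two numbers cannot be told apart. For the measured compounds named here, the single measured step, a number 2 percentage points higher from compound 1 to compound 2 (within the scatter), concerns a hydrogen in place of a methoxy on an aromatic carbon and is within the scatter.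

Compound 3 `COc1ccc(C(=O)/C=C/c2cc(-c3cc(OC)c(OC)c(OC)c3)n[nH]2)cc1OC` has not yet been measured in this assay. It differs from compound 1 in one place: 3,4-dimethoxyphenyl in place of 4-aminophenyl on a carbonyl carbon. Going by the values given here, no measured step touches the carbonyl-bearing side of the shared core, so the only step available, a number 2 percentage points higher from compound 1 to compound 2 (within the scatter), bears on the change at most indirectly, and it was within the scatter. On these data alone no step beyond the scatter is expected for compound 3 in this assay.

Compound 3 is therefore estimated at 85%, with an expected range from 65% to 98%. This estimate amounts to an expected step of a number 2 percentage points higher from compound 1 to compound 3 (within the scatter), which is within the scatter.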

Compound 3, a percentage reported as activity, at one concentration (the size of the read-out at that concentration, not a potency): 93%
The estimate for compound 3 lay 8 percentage points below the measured number; the measured number falls inside the stated range.
By their numbers in this assay, from the lowest: compounds 1, 2 and 3 (each within the scatter of the next).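

In this assay, among the compounds shown here, the exchange of 4-aminophenyl for 3,4-dimethoxyphenyl on a carbonyl carbon gives a number 10 percentage points higher from compound 1 to compound 3 (within the scatter), and this is the first measured change on that side of the shared core. The earlier pair spoke only to a methoxy on the other aromatic ring, whereas this pair shows that the amino group can be replaced at this position without the read-out moving beyond the scatter, although the step lies at the upper edge of what the scatter allows and rests on a single pair at a single concentration. No measurement of any property of these groups is available to bear on this result.

The compounds shown leave open whether other groups on this carbonyl carbon, such as an unsubstituted phenyl, a 4-hydroxyphenyl or a phenyl carrying a carboxylic acid, would give a number beyond the scatter. They also leave open whether the same exchange would behave alike on the core of compound 2, and how any of these compounds would read at a higher concentration.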